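Replacing 2-hydroxypropyl by an oxane carbonyl: expected cytotoxicity

A few compounds are considered here, and "the series" means these few. Any claim that something is new, unique, unknown or untested is made for them only; others in the source may bear on it.

The measured compounds are:
compound 1, `CC(C)=CC[C@@H](OC[C@H](C)O)C1=CC(=O)c2c(O)ccc(O)c2C1=O`, with 24500 nM in a functional assay on DU-145 cells (Homo sapiens) for cytotoxicity, read by MTT assay; a lower number here means a stronger inhibitor, a higher number a weaker inhibitor;
compound 2, `CCCCC(O)CC(=O)O[C@H](CC=C(C)C)C1=CC(=O)c2c(O)ccc(O)c2C1=O`, with 45300 nM;
compound 3, `CC(C)=CC[C@@H](OC(=O)CC(O)c1ccccc1)C1=CC(=O)c2c(O)ccc(O)c2C1=O`, with 17000 nM.

Compound 1 stands second highest of the three numbers; its nearest neighbour is compound 3, and the whole spread from compound 1 to compound 2 and to compound 3 is within the scatter. Compound 4, `CC(C)=CC[C@@H](OC(=O)C1CCCCO1)C1=CC(=O)c2c(O)ccc(O)c2C1=O`, differs from compound 1 by (oxan-2-yl)carbonyl in place of 2-hydroxypropyl on an oxygen on a saturated carbon.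

Going by the values given here, one measured step bears on this change: a 1.8-fold higher number from compound 1 to compound 2 (0.27 log units; within the scatter), where an acyl group with a carbonyl likewise took the place of 2-hydroxypropyl on the same oxygen, and no step beyond the scatter resulted. The step of a 2.7-fold lower number from compound 2 to compound 3 (0.43 log units; beyond the scatter) was modest and concerned only the end of the chain. Neither step suggests that a carbonyl on this oxygen shifts the number much, so for compound 4 a step of no more than the scatter is expected, a 1.1-fold higher number from compound 1 to compound 4 (0.03 log units; within the scatter). Compound 4 is therefore estimated at 26000 nM, with a range from 10000 nM to 65000 nM.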

Compound 4, half-maximal inhibitory concentration: 24700 nM
For compound 4 the middle estimate is 1.1-fold (0.02 log units) above the measured one, within the range that was stated.
By their numbers in this assay, from the lowest: compounds 3, 1, 4 and 2 (each within the scatter of the next, the first and the last beyond it).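

In this assay, the change to (oxan-2-yl)carbonyl on this oxygen gives (a 1.0-fold higher number from compound 1 to compound 4 (0.00 log units; within the scatter)), so a group with one six-membered non-aromatic ring and 0 hydrogen-bond donors leaves the number within the scatter of 2-hydroxypropyl. The earlier acyl groups all carried a hydroxy group, and oxan-2-yl on the carbonyl carbon, which has none, also stays within the scatter of both 2-hydroxy-2-phenylethyl (a 1.5-fold higher number from compound 3 to compound 4 (0.16 log units; within the scatter)) and 2-hydroxyhexyl (a 1.8-fold lower number from compound 2 to compound 4 (0.26 log units; within the scatter)), even though compound 2 and compound 3 lie beyond the scatter of each other. No measurement shown here explains why the number stays put at this position.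

The change from compound 1 to compound 4 brings in the carbonyl and the ring together, so the share of each cannot be read. On these data alone, whether an acyl group bearing an amine or a carboxylic acid would move the number beyond the scatter also remains open.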